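Swapping a piperazine for dimethylamino on the shared core

A few compounds are considered here, and "the series" means these few. Any claim that something is new, unique, unknown or untested is made for them only; others in the source may bear on it.

Compound 1 `Cc1ccc2nc(N(C)C)nc(NCc3ccc(C(=O)N[C@H]4C[C@@H]4c4ccccc4)cc3)c2c1`: 1300 nM
Compound 2 `Cc1ccc2nc(N3CCNC(C)C3)nc(NCc3ccc(C(=O)NCc4ccc(F)cc4)cc3)c2c1`: 2900 nM

Both values come from a functional assay on HCT-116 cells (Homo sapiens) for inhibition, read by luminescence and resazurin assay, with a stated time of 3 days; on this read-out lower numbers stand for stronger inhibition and higher numbers for weaker inhibition. Of these two compounds, compound 2 has the higher number at 2900 nM, and its gap to compound 1 lies beyond the usual scatter of repeated measurements. The two compounds differ in more than one place, so this gap cannot be assigned to any single group.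

Compound 3 `Cc1ccc2nc(N(C)C)nc(NCc3ccc(C(=O)NCc4ccc(F)cc4)cc3)c2c1` departs from compound 2 in a single place: dimethylamino in place of 3-methylpiperazin-1-yl on an aromatic carbon. Dimethylamino takes the place of 3-methylpiperazin-1-yl on an aromatic carbon, between two ring nitrogen atoms. For the measured compounds named here, no measured pair isolates this change. Compound 1 also carries dimethylamino there and gives 1300 nM, but it differs from compound 3 elsewhere and is only a loose guide. In this assay, the expected step of a 1.5-fold lower number from compound 2 to compound 3 (0.18 log units; within the scatter) is small and toward a lower number, and it may well stay within the scatter. For compound 3 the estimated value is 1900 nM, with an expected range of 700 nM to 5000 nM.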

Compound 3, half-maximal inhibitory concentration: 900 nM
For compound 3 the middle estimate is 2.1-fold (0.32 log units) above the measured one; the measured number falls inside the stated range.
By their numbers in this assay, from the lowest: compounds 3 and 1 (each within the scatter of the next); then compound 2.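

In this assay, for the compounds shown here, putting dimethylamino in place of 3-methylpiperazin-1-yl on the aromatic carbon between two ring nitrogen atoms gives a 3.2-fold lower number from compound 2 to compound 3 (0.51 log units; beyond the scatter), which is beyond the scatter and is the first comparison to isolate this position. The exchange removes the six-membered non-aromatic ring and its hydrogen-bond donor together, and leaves a smaller group of 3 heavy atoms, so the shown step belongs to the whole replacement and not to any one of these features. With dimethylamino on the shared core, 4-fluorobenzyl in place of 2-phenylcyclopropyl on the amide-type nitrogen gives a 1.4-fold lower number from compound 1 to compound 3 (0.16 log units; within the scatter), which is within the scatter, so these two amide substituents cannot be told apart in this setting. Nothing beyond these cell numbers bears on why the step at the aromatic carbon occurs.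

From the compounds shown here alone, it remains open whether morpholine, pyrrolidine or an unsubstituted piperazine at this position would read like dimethylamino or like 3-methylpiperazin-1-yl. It is also open whether the step would repeat with 2-phenylcyclopropyl on the amide-type nitrogen, since the compounds shown pair that group only with dimethylamino.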